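Swapping bromo for iodo on a corticotropin-releasing factor ligand

The source may report more compounds than this note shows. Statements on the series, on what has been measured and on what is new or still open speak of the compounds shown alone.

Measured so far:
- compound 1, `Cc1cc(Cl)nc2c1ccn2-c1ccc(C(C)C)cc1Br`, 79 nM in an assay on isolated protein for binding affinity to corticotropin-releasing factor receptor 1 (Rattus norvegicus); a lower number here means a stronger inhibitor, a higher number a weaker inhibitor
- compound 2, `CCN(c1nc(C)cc(C)n1)c1ccc(C(C)C)cc1Br`, 46 nM in this assay

Compound 2 has the lowest of the two numbers, but compound 1 sits only a short distance away, and that distance is within the scatter of this assay, so the two values cannot be told apart with confidence. Going by the values given here, the two compounds also differ in more than one place, so no single structural step between them is counted here.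

Compound 3, `CCN(c1nc(C)cc(C)n1)c1ccc(C(C)C)cc1I`, is not yet measured. It differs from compound 2 in one place: iodo in place of bromo on an aromatic carbon. Among the compounds with values here, nothing among the measured compounds shows what this exchange of one halogen for another does, so no direction is given by the data. A step of this kind, one heavy atom for another of the same family at the same place, is usually small, and the expectation is a change within the scatter, with no clear direction. The estimate for compound 3 is 40 nM, with a range from 15 nM to 120 nM, which corresponds to an expected step of a 1.2-fold lower number from compound 2 to compound 3 (0.06 log units; within the scatter).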

Compound 3, inhibition constant: 38 nM
Estimate against measurement, compound 3: 1.1-fold (0.02 log units) above; measured number inside the range.
By their numbers in this assay, from the lowest: compounds 3, 2 and 1 (each within the scatter of the next, the first and the last beyond it).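

Going by these compounds alone, on the aromatic carbon ortho to a large group and meta to an isopropyl group, putting iodo in place of bromo gives a 1.2-fold lower number from compound 2 to compound 3 (0.08 log units; within the scatter) in this assay and so offers the first comparison here in which only one place differs. Since this step lies within the scatter, the two compounds cannot be separated by this measurement, and either halogen at this carbon is compatible with a reading of the same size in this assay (at least for these two halogens on this particular scaffold). Nothing measured here explains why this exchange leaves the two readings indistinguishable, so the result records an outcome without giving a reason for it.

Both compounds carry a halogen at this carbon, so the compounds shown leave open whether a halogen is needed there at all, or whether a plain hydrogen, a fluoro or chloro group, a methoxy group, a nitrile or an amine would give a similar number. They also leave open whether the same indifference would hold with a different group in place of the isopropyl group, such as a longer chain or a cyclopropyl ring.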